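Adding a Second Chlorine to a Urea Series

The source may report more compounds than this note shows. Statements on the series, on what has been measured and on what is new or still open speak of the compounds shown alone.

Measured so far:
- compound 1 `CN(C)CCNc1nc(-c2ccc(NC(=O)Nc3ccc(Cl)cc3)cc2)nc2ccsc12`: 310 nM
- compound 2 `CN(C)CCNc1nc(-c2ccc(NC(=O)Nc3ccc(Cl)cc3Cl)cc2)nc2ccsc12`: 2450 nM
- compound 3 `CCN(CC)CCNc1nc(-c2ccc(NC(=O)Nc3ccccc3Cl)cc2)nc2ccsc12`: 680 nM

In a functional assay on MDA-MB-231 cells (Homo sapiens) for cytotoxicity, read by MTT assay, with a stated time of 72 h (a higher number here means a weaker inhibitor, a lower number a stronger inhibitor), compound 1 gives 310 nM. Compound 2 differs from it by chloro in place of hydrogen on an aromatic carbon and the step was a 7.9-fold higher number from compound 1 to compound 2 (0.90 log units; beyond the scatter). Compound 3 has a different core, and the difference between the two cores is not broken down here; in this assay compound 3 gives 680 nM.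

Compound 4 `CCN(CC)CCNc1nc(-c2ccc(NC(=O)Nc3ccc(Cl)cc3Cl)cc2)nc2ccsc12` has not yet been measured. It differs from compound 3 by chloro in place of hydrogen on an aromatic carbon. Among the compounds with values here, this is the same kind of change as the one from compound 1 to compound 2, but not the same: in the earlier pair the entering chloro sits ortho to a large group and meta to a chloro group, whereas here it sits meta to a chloro group and para to a large group.

The step is expected to be a 4.4-fold higher number from compound 3 to compound 4 (0.64 log units; beyond the scatter), resting on compound 1, where the same kind of change gave a 7.9-fold higher number from compound 1 to compound 2 (0.90 log units; beyond the scatter), tempered a little for the different surroundings. Compound 4 is therefore estimated at 3000 nM, between 1200 nM and 8000 nM.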

Compound 4, half-maximal inhibitory concentration: 2480 nM
Estimate against measurement, compound 4: 1.2-fold (0.08 log units) above; the measured number falls inside the stated range.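

The added chloro, going from 2-chlorophenyl to 2,4-dichlorophenyl, weakens the compound on this second core too, with a 3.6-fold higher number from compound 3 to compound 4 (0.56 log units; beyond the scatter), and the two steps agree in direction and, given the usual scatter, in size: the same change on two cores in this assay, a 7.9-fold higher number (0.90 log units; beyond the scatter) from compound 1 to compound 2 and a 3.6-fold higher number (0.56 log units; beyond the scatter) from compound 3 to compound 4, 2.2-fold (0.34 log units) apart, within the scatter of two such steps Swapping dimethylamino for diethylamino with the 2,4-dichlorophenyl group in place gives a 1.0-fold higher number from compound 2 to compound 4 (0.01 log units; within the scatter), so these two compounds cannot be told apart. Within the data shown here, this shows that the penalty carried over between these two cores, but it rests on only two pairs, the entering chloro does not sit in the same place in each, and it does not explain why the number rises or show that the same would hold on any other core.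

As far as these compounds go, it remains open whether the step would keep its size with a different amine at the end of the chain, such as a pyrrolidine or a morpholine, or with a longer chain. From the compounds shown here alone, it is also open whether a second substituent other than chloro, such as fluoro or methoxy, would cost as much.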